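The source may hold more compounds than are shown below. What is called first, only, known or untested is meant among the compounds shown, and "the series" means these compounds.

Compound 1 `Cc1oc(C(=O)O)cc1COc1ccc(-c2ccc(CO)cc2)cc1` is a carboxylic acid; in an assay on cells for displacement of a labelled ligand from prostaglandin E2 receptor EP4 subtype (Homo sapiens), read by scintillation counting (on this read-out lower numbers stand for stronger inhibition and higher numbers for weaker inhibition), compound 1 gives 3000 nM, the highest of the three numbers measured. For the measured compounds named here, compound 2 `COc1ccc(-c2ccc(OCc3cc(C(=O)NS(=O)(=O)c4ccc(C)cn4)oc3C)cc2)cc1` gives 15 nM, and compound 3 `COc1ccc(-c2ccc(OCc3cc(C(=O)NS(=O)(=O)Cc4ccccc4)oc3C)cc2)cc1` gives 3 nM; the only one-place step among the measured compounds is a 5.0-fold lower number from compound 2 to compound 3 (0.70 log units; beyond the scatter). Both of these carry an acylsulfonamide in place of the acid of compound 1 and a methoxy group where compound 1 carries hydroxymethyl, so they share two differences with it at once and say little about either change alone.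

Compound 4 `Cc1oc(C(=O)O)cc1COc1ccc(-c2ccccc2)cc1` differs from compound 1 in one place: hydrogen in place of hydroxymethyl on an aromatic carbon. Going by the values given here, no measured step touches this change, and the gap from compound 1 to compound 2 or compound 3 cannot be split between the two changes it contains. Removing a small group usually changes binding only a little, so the step of a 1.5-fold higher number from compound 1 to compound 4 (0.18 log units; within the scatter) is expected to stay close to the scatter, most likely toward a slightly higher number. Compound 4 is therefore estimated at 4500 nM, within a range of 1500 nM to 14000 nM.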

Compound 4, inhibition constant: 420 nM
The estimate for compound 4 lay 11-fold (1.03 log units) above the measured number, and the stated range ends above it.
By their numbers in this assay, from the lowest: compound 3; then compound 2; then compound 4; then compound 1.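

Replacing 4-(hydroxymethyl)phenyl with phenyl gives a 7.1-fold lower number from compound 1 to compound 4 (0.85 log units; beyond the scatter) in this assay, so this hydroxymethyl, para to a large group, is not needed for binding in this carboxylic acid, and inhibition is stronger with hydrogen in its place. For the compounds shown here, this is the first change at this position that can be read alone: compound 2 and compound 3 differ from compound 1 in the acid as well as in this group. No measurement at hand explains why losing the hydroxymethyl strengthens inhibition.

On these data alone, how the methoxy group of compound 2 and compound 3 compares with hydrogen at this place remains open, as does whether the same change gives a step of similar size in an acylsulfonamide. An aminomethyl group or a chlorine atom at this place also remains untested among the compounds shown.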